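Replacing the 3-Bromophenyl Group of Compound 1

The compounds below may be only part of what the source reports. "The series", "measured", "known", "first", "only" and "open" are said of these compounds alone.

Among the compounds with values here, in a functional assay on HGC-27 cells (Homo sapiens) for inhibition, read by MTT assay, with a stated time of 72 h (a higher number here means a weaker inhibitor, a lower number a stronger inhibitor), compound 1 `C=C[C@]1(C)C[C@@H](OC(=O)CNC(=O)Nc2cccc(Br)c2)[C@]2(C)[C@H](C)CC[C@]3(CCC(=O)[C@H]32)[C@@H](C)[C@@H]1O` gives 3950 nM, the strongest result and the only exact number so far. Compound 2 `C=C[C@]1(C)C[C@@H](OC(=O)CNC(=O)NC(=O)c2cccc(F)c2)[C@]2(C)[C@H](C)CC[C@]3(CCC(=O)[C@H]32)[C@@H](C)[C@@H]1O` reaches only a limit of the assay, > 10000 nM. Compound 3 `C=C[C@]1(C)C[C@@H](OC(=O)CNC(=O)Nc2ccc(Cl)cc2)[C@]2(C)[C@H](C)CC[C@]3(CCC(=O)[C@H]32)[C@@H](C)[C@@H]1O` also reaches only a limit, > 10000 nM.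

Compound 4 `C=C[C@]1(C)C[C@@H](OC(=O)CNC(=O)Nc2ccc(F)cc2F)[C@]2(C)[C@H](C)CC[C@]3(CCC(=O)[C@H]32)[C@@H](C)[C@@H]1O` carries 2,4-difluorophenyl in place of 3-bromophenyl on an amide-type nitrogen. Two measured replacements at that place weakened inhibition beyond the scatter: an at least 2.5-fold higher number from compound 1 to compound 2 (0.40 log units; beyond the scatter) with (3-fluorophenyl)carbonyl, and an at least 2.5-fold higher number from compound 1 to compound 3 (0.40 log units; beyond the scatter) with 4-chlorophenyl. Both sizes are only minimums, set by the limit of > 10000 nM in this assay, at which 2 of the 3 values shown sit. A similar weakening is therefore expected, an estimated 2.3-fold higher number from compound 1 to compound 4 (0.36 log units; beyond the scatter). The estimate for compound 4 is 9000 nM, with an expected range from 3500 nM to 25000 nM.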

Compound 4, half-maximal inhibitory concentration: > 10000 nM
Compound 4 gave a limit, no number (the forecaster's own chance of this, stated with the estimate: 45%); at least 1.1-fold (0.04 log units) between middle value and limit.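

The 2,4-difluorophenyl group is a third replacement at this amide-type nitrogen that weakens inhibition, with an at least 2.5-fold higher number from compound 1 to compound 4 (0.40 log units; beyond the scatter), and this size is again only a minimum. Within the data shown here, the 3-bromophenyl group of compound 1 therefore remains the only group here with an exact value. The steps among compound 2, compound 3 and compound 4 cannot be read, since each of these compounds gives a limit and not a number: the limit of > 10000 nM in this assay, at which 3 of the 4 values shown sit.

From the compounds shown here alone, what a plain phenyl group or a longer chain ending in an amine would give at this nitrogen remains open. So does whether any group here could inhibit more strongly than 3-bromophenyl.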